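Replacing the Benzoxazolyl Sulfide Group in Compound 1

This account rests on a few compounds, and the source may have more. Where it says the series, first, only, none or still open, it means among the compounds named here.

Compound 1 `Cn1c(-c2ccc(NC(=O)CSc3nc4ccccc4o3)cc2)nc(-c2ccccc2)c1-c1ccccc1` was tested in a functional assay on HT-29 cells (Homo sapiens) for cytotoxicity, read by MTT assay, with a stated time of 24 h, tested at 6.4 ug/mL (a higher number here means a stronger effect of the compound at the concentration tested, a lower number a weaker effect), where compound 1 gives 44.9%. Compound 2 `Cn1cnnc1SCC(=O)Nc1ccc(-c2nc(-c3ccccc3)c(-c3ccccc3)n2C)cc1` gives 43.1% and compound 3 `Cc1nnc(SCC(=O)Nc2ccc(-c3nc(-c4ccccc4)c(-c4ccccc4)n3C)cc2)s1` gives 73%. Compound 1 therefore sits close to compound 2, while compound 3 stands well above both, the steps being a number 28.1 percentage points higher from compound 1 to compound 3 (beyond the scatter) and a number 29.9 percentage points higher from compound 2 to compound 3 (beyond the scatter). Compound 4 `Cn1c(-c2ccc(NC(=O)CSC3=NCCS3)cc2)nc(-c2ccccc2)c1-c1ccccc1` carries a group of 5 heavy atoms (3 carbon, 1 nitrogen, 1 sulfur; one five-membered non-aromatic ring with 2 hetero atoms) in place of a group of 9 heavy atoms (7 carbon, 1 nitrogen, 1 oxygen; one five-membered aromatic ring with 2 hetero atoms, one six-membered aromatic ring of carbon only), on a sulfur. Among the measured compounds shown here, no measured step covers this non-aromatic group; the two steps that exchange the group on the same sulfur gave a number 1.8 percentage points lower from compound 1 to compound 2 (within the scatter) and a number 28.1 percentage points higher from compound 1 to compound 3 (beyond the scatter), so in this assay only a small to modest change is expected, more likely within the scatter. For compound 4 the expected value is 48%, with a range from 30% to 70%. This expectation corresponds to a number 3.1 percentage points higher from compound 1 to compound 4 (within the scatter).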

Compound 4, a percentage reported as activity, at one concentration (the size of the read-out at that concentration, not a potency): 31%
Compound 4: middle estimate off by 17 percentage points, on the high side, within the range that was stated.
By their numbers in this assay, from the lowest: compound 4; then compounds 2 and 1 (each within the scatter of the next); then compound 3.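

In this assay, among the compounds shown here, the non-aromatic ring group on the sulfur gives the first exchange that falls beyond the scatter on the low side from compound 1 (a number 13.9 percentage points lower from compound 1 to compound 4 (beyond the scatter)). It also stands below the two other groups (a number 12.1 percentage points lower from compound 2 to compound 4 (beyond the scatter); a number 42 percentage points lower from compound 3 to compound 4 (beyond the scatter)), so this position allows clear changes in both directions and compound 4 is the lowest of the set. Nothing measured here explains this drop.

Going by these compounds, whether a thiazol-2-yl group or an open-chain amine on the same sulfur would stand nearer compound 3 or compound 4 remains open.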